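A few compounds are considered here, and "the series" means these few. Any claim that something is new, unique, unknown or untested is made for them only; others in the source may bear on it.

Measured compounds:
compound 1, `CCCC(=O)Nc1cccc(S(=O)(=O)Oc2ccccc2C(C)C)c1`, 15000 nM in a functional assay on HT-1080 cells (Homo sapiens) for antiproliferative activity, read by sulforhodamine B assay, with a stated time of 48 h; a higher number here means a weaker inhibitor, a lower number a stronger inhibitor
compound 2, `CC(C)c1ccccc1OS(=O)(=O)c1ccc(NC(=O)CCl)cc1`, 1000 nM
compound 3, `O=C(CCl)Nc1ccc(S(=O)(=O)Oc2ccccc2I)cc1`, 600 nM

Compound 3 gives the lowest number of the three in this assay. Its nearest neighbour is compound 2, and the step of a 1.7-fold lower number from compound 2 to compound 3 (0.22 log units; within the scatter) lies within the scatter, so the two cannot be ordered. Compound 1 stands far from it, a distance beyond the scatter.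

The unmeasured compound 4, `O=C(NCCCCl)Nc1ccc(S(=O)(=O)Oc2ccccc2I)cc1`, differs from compound 3 in one place: (3-chloropropyl)amino in place of chloromethyl on a carbonyl carbon. Among the compounds with values here, no measured step covers this change. Within the data shown here, the only step available, a 1.7-fold lower number from compound 2 to compound 3 (0.22 log units; within the scatter), concerns a different position and says nothing about the carbonyl side. Among the measured compounds shown here, compound 1 carries a plain butanoyl group where compound 2 and compound 3 carry a chloroacetyl group, but compound 1 also differs in where the acylamino group sits on its ring, so its values with compound 2 show only that two changes together went with a much weaker result.

With nothing directly to lean on, compound 4 is expected to give a higher number than compound 3, by a step of about a 5.0-fold higher number from compound 3 to compound 4 (0.70 log units; beyond the scatter). The estimate for compound 4 in this assay is 3000 nM, within a range from 700 nM to 15000 nM.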

Compound 4, half-maximal inhibitory concentration: 2800 nM
Beside the measured number, compound 4's estimate is 1.1-fold (0.03 log units) above it; the measured number falls inside the stated range.
By their numbers in this assay, from the lowest: compounds 3 and 2 (each within the scatter of the next); then compound 4; then compound 1.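

In this assay, within the data shown here, the step of a 4.7-fold higher number from compound 3 to compound 4 (0.67 log units; beyond the scatter) is beyond the scatter and is the first reading of a single change on the carbonyl side, where the earlier compounds offered only a step elsewhere on the molecule and a comparison in which two changes went together. It shows that this position responds to the change from chloromethyl to (3-chloropropyl)amino, and that the response is a weaker result, though compound 4 still gives a finite 2800 nM. The entering group differs from chloromethyl in both its chain and its nitrogen with a hydrogen-bond donor, the compounds offer no way to divide the step among these differences, and no measurement shown accounts for it.

The compounds shown leave open whether the chain or the nitrogen goes with the weaker result, which a 4-chlorobutyl group on the same carbonyl carbon or a plain propylamino group without the chlorine would help to separate. They also leave open whether the same step would appear with isopropyl in place of iodo on the shared core.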